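The source may report more compounds than this note shows. Statements on the series, on what has been measured and on what is new or still open speak of the compounds shown alone.

Measured in a functional assay on HCT-116 cells (Homo sapiens) for inhibition, read by MTT assay, with a stated time of 48 h; a lower number here means a stronger inhibitor, a higher number a weaker inhibitor:
- Compound 1 `Cc1nnsc1CO/N=C/c1c(C)nn(C)c1Oc1ccc(I)cc1`: 43800 nM
- Compound 2 `Cc1nnsc1CO/N=C/c1c(C)nn(C)c1Oc1ccc(OC(F)(F)F)cc1`: 12800 nM
- Compound 3 `Cc1nnsc1CO/N=C/c1c(C)nn(C)c1Oc1ccc(C(C)(C)C)cc1`: 33500 nM

Compound 1 sits at the upper end of these numbers, but it has a close neighbour: a 1.3-fold lower number from compound 1 to compound 3 (0.12 log units; within the scatter). The widest gap among the three is modest: a 3.4-fold lower number from compound 1 to compound 2 (0.53 log units; beyond the scatter). A gap of similar, modest size appears in a 2.6-fold higher number from compound 2 to compound 3 (0.42 log units; beyond the scatter).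

Compound 4 `Cc1nnsc1CO/N=C/c1c(C)nn(C)c1Oc1cc(F)cc(F)c1` has not yet been measured. It keeps the core of compound 1 and carries 3,5-difluorophenyl in place of 4-iodophenyl on an oxygen on an aromatic ring.

The three measured steps all exchange one group on an aromatic carbon of this ring, so they bear on the change and give its likely scale. None of them involves 3,5-difluorophenyl, however, so they give that scale only loosely. With compound 1 at 43800 nM, a shift to a lower number seems somewhat likelier than one to a higher number, but no step beyond the scatter is expected in this assay. The expected step is a 1.6-fold lower number from compound 1 to compound 4 (0.19 log units; within the scatter). Compound 4 is estimated at 28000 nM, with an expected range from 11000 nM to 70000 nM.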

Compound 4, half-maximal inhibitory concentration: 8120 nM
Compound 4: middle estimate off by 3.4-fold (0.54 log units), on the high side, outside the stated range (below it).
By their numbers in this assay, from the lowest: compounds 4 and 2 (each within the scatter of the next); then compounds 3 and 1 (each within the scatter of the next).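

In this assay, the replacement of the whole substituted phenyl gives a 5.4-fold lower number from compound 1 to compound 4 (0.73 log units; beyond the scatter), so this position on the oxygen accepts a ring with two fluorines and no iodine or other single large group, with a gain beyond the scatter. Among the earlier compounds, only the trifluoromethoxy group had moved the number beyond the scatter from compound 1, and now compound 2 at 12800 nM and compound 4 at 8120 nM lie within the scatter of each other, which shows that two quite different groups on this ring can reach the same level in this assay. Nothing available explains why this change shifts the number.

Since the iodine was lost and two fluorines were gained in a single step, the compounds shown cannot separate the contribution of the fluorines from that of their placement on the ring. They also leave open how this position would respond to a phenyl with a single fluorine, or to a ring carrying an amine or a carboxylic acid.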